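Adding an ethoxy group to a phenyl ring: what to expect

The source may hold more compounds than are shown below. What is called first, only, known or untested is meant among the compounds shown, and "the series" means these compounds.

Measured so far in a functional assay on L1210 cells (Mus musculus) for antiproliferative activity; a higher number here means a weaker inhibitor, a lower number a stronger inhibitor:
- compound 1, `COc1cc(C(=O)c2sc(-c3ccc(Cl)cc3)cc2N)cc(OC)c1OC`: 93 nM
- compound 2, `COc1cc(C(=O)c2sc(-c3ccccc3)cc2N)cc(OC)c1OC`: 11 nM
- compound 3, `COc1cc(C(=O)c2sc(-c3ccccc3Cl)cc2N)cc(OC)c1OC`: 20 nM

Compound 2 gives the lowest number of the three. Its nearest neighbour is compound 3, and the step of a 1.8-fold higher number from compound 2 to compound 3 (0.26 log units; within the scatter) is within the scatter, so these two cannot be ranked against each other. Compound 1 stands further away: the step of an 8.5-fold lower number from compound 1 to compound 2 (0.93 log units; beyond the scatter) is beyond the scatter, as is a 4.7-fold lower number from compound 1 to compound 3 (0.67 log units; beyond the scatter).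

The new compound 4, `CCOc1ccc(-c2cc(N)c(C(=O)c3cc(OC)c(OC)c(OC)c3)s2)cc1`, differs from compound 2 in one place: ethoxy in place of hydrogen on an aromatic carbon. Among the measured compounds shown here, the only measured step that touches a group in this position is an 8.5-fold lower number from compound 1 to compound 2 (0.93 log units; beyond the scatter), where a chloro group sat on the same carbon and its removal lowered the number considerably. For the measured compounds named here, an ethoxy group is a different kind of substituent, and no measured compound carries one, so the direction is borrowed from the chloro case with caution. A modestly higher number than that of compound 2 is therefore expected for compound 4, with a step of a 3.6-fold higher number from compound 2 to compound 4 (0.56 log units; beyond the scatter). The estimate for compound 4 in this assay is 40 nM, within 12 nM to 130 nM.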

Compound 4, half-maximal inhibitory concentration: 590 nM
Compound 4: the middle estimate sits 15-fold (1.17 log units) below what was measured, and the stated range ends below it.
By their numbers in this assay, from the lowest: compounds 2 and 3 (each within the scatter of the next); then compound 1; then compound 4.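

In this assay the carbon para to a large group now looks much less forgiving than the chloro case alone suggested, since a 54-fold higher number from compound 2 to compound 4 (1.73 log units; beyond the scatter) is a large loss for adding ethoxy in place of hydrogen. Both groups placed here raise the number, but they do not cost the same: a 6.3-fold higher number from compound 1 to compound 4 (0.80 log units; beyond the scatter) separates ethoxy from chloro by more than the scatter. The swap to the 4-ethoxyphenyl group from the 2-chlorophenyl group is also large, with a 30-fold higher number from compound 3 to compound 4 (1.47 log units; beyond the scatter) as its step. Nothing at hand accounts for the size of this loss.

From the compounds shown here alone, whether a methoxy group or a longer chain such as propoxy on this carbon would fall nearer compound 2 or compound 4 remains open. So does whether ethoxy on another carbon of this ring would cost as much.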